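Compound 1 and an Untested Acetyl Swap

A few compounds are considered here, and "the series" means these few. Any claim that something is new, unique, unknown or untested is made for them only; others in the source may bear on it.

Compound 1 `CCOc1ccc(N/N=C2\CCC(C)n3c2ncc(C(=O)O)c3=O)cc1`: 17600 nM
Compound 2 `CCOc1ccc(N/N=C2\CC[C@@H](C)n3c2ncc(C(=O)O)c3=O)cc1`: 1000 nM
Compound 3 `CCOc1ccc(N/N=C2\CC[C@H](C)n3c2ncc(C(=O)O)c3=O)cc1`: 19200 nM

In a functional assay (mast cells) for inhibition, with Rattus norvegicus as the target (a lower number here means that less compound is needed, a higher number that more compound is needed for the effect), compound 1 sits at the high end of this small set. The step of a 1.1-fold higher number from compound 1 to compound 3 (0.04 log units; within the scatter) stays within the scatter, while the step of an 18-fold lower number from compound 1 to compound 2 (1.25 log units; beyond the scatter) is large. Compound 4 `CC(=O)c1ccc(N/N=C2\CCC(C)n3c2ncc(C(=O)O)c3=O)cc1` has acetyl in place of ethoxy on an aromatic carbon, para to a large group: acetyl in place of ethoxy on an aromatic carbon.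

The measured steps bear on this change only weakly. All of them concern the configuration at a saturated ring carbon. The largest, a 19-fold higher number from compound 2 to compound 3 (1.28 log units; beyond the scatter), goes with the fact that compounds 2 and 3 differ only in the configuration as drawn. None of them alters the aromatic substituent, so they give neither a size nor a direction for this swap. The expectation therefore stays close to compound 1 at 17600 nM, with a wide margin. The expected step is a 1.2-fold lower number from compound 1 to compound 4 (0.07 log units; within the scatter), which means none beyond the scatter in this assay. The estimate for compound 4 is 15000 nM, within an expected range of 3000 nM to 75000 nM.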

Compound 4, half-maximal effective concentration: 8100 nM
Estimate against measurement, compound 4: 1.9-fold (0.27 log units) above, and the stated range covers the measured number.
By their numbers in this assay, from the lowest: compound 2; then compound 4; then compounds 1 and 3 (each within the scatter of the next).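

Within the data shown here, until now, only the configuration at a saturated ring carbon had varied, so this is the first reading on the aromatic substituent: in this assay, acetyl in place of ethoxy gives a 2.2-fold lower number from compound 1 to compound 4 (0.34 log units; beyond the scatter). The position therefore responds to a swap of groups, though modestly, and the two groups match in heavy atoms, hydrogen-bond donors and hydrogen-bond acceptors, differing in the count of double bonds outside aromatic rings. Nothing measured here explains this step.

From the compounds shown here alone, compound 4 is drawn without a configuration at the saturated ring carbon, so whether the gain from acetyl carries over to the configuration of compound 2 remains open. Also open, going by these compounds, is how this position would respond to an amine, a carboxylic acid or a longer chain such as butoxy.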